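This account rests on a few compounds, and the source may have more. Where it says the series, first, only, none or still open, it means among the compounds named here.

In a functional assay on A549 cells (Homo sapiens) for cytotoxicity, read by sulforhodamine B assay (on this read-out higher numbers stand for an effect only at larger amounts of compound and lower numbers for an effect already at smaller amounts), compound 1 `O=C1CC(c2ccccc2)Nc2ccccc21` gives 0.013 ug/mL, compound 2 `COc1cccc(C2CC(=O)c3ccccc3N2)c1` gives 0.23 ug/mL and compound 3 `COc1cccc([C@@H]2CC(=O)c3ccccc3N2)c1` gives 0.15 ug/mL. Compound 2 thus stands at the high end of these numbers, within the scatter of compound 3 and well beyond it from compound 1. Methoxy in place of hydrogen on an aromatic carbon is the single change in an 18-fold higher number from compound 1 to compound 2 (1.25 log units; beyond the scatter), a large step. The other measured step, a 1.5-fold lower number from compound 2 to compound 3 (0.19 log units; within the scatter), stays within the scatter and concerns only (the fact that one of compounds 2 and 3 is drawn with a defined configuration and the other without, at the place where they differ), so it says little here.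

Compound 4 `COc1cccc(C2CC(=O)c3cc(N4CCCC4)ccc3N2)c1` differs from compound 2 by pyrrolidin-1-yl in place of hydrogen on an aromatic carbon, with pyrrolidin-1-yl in place of hydrogen on an aromatic carbon of the part of the fused system that is a six-membered aromatic ring of carbon only. Within the data shown here, the nearest precedent is an 18-fold higher number from compound 1 to compound 2 (1.25 log units; beyond the scatter), but that replacement lies on a different ring and a different group enters, so its size warns of a possibly large shift without fixing the direction. The expected change is a 2.3-fold lower number from compound 2 to compound 4 (0.36 log units; beyond the scatter), a tentative estimate that could fall on either side. For compound 4 the estimated value in this assay is 0.1 ug/mL, with an expected range of 0.01 ug/mL to 1 ug/mL.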

Compound 4, concentration for half-maximal effect: 0.01 ug/mL
Estimate against measurement, compound 4: 10-fold (1.00 log units) above, and the stated range covers the measured number.
By their numbers in this assay, from the lowest: compounds 4 and 1 (each within the scatter of the next); then compounds 3 and 2 (each within the scatter of the next).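

In this assay, among these compounds, pyrrolidin-1-yl in place of hydrogen on the six-membered aromatic ring of carbon only, para to a fused ring, gives a 23-fold lower number from compound 2 to compound 4 (1.36 log units; beyond the scatter), so this position of the fused system, untouched in the earlier compounds, accepts a ring substituent and the number falls. The methoxy change on the other ring moved the number the opposite way, with an 18-fold higher number from compound 1 to compound 2 (1.25 log units; beyond the scatter), so the two places in the series respond differently to substitution. Nothing at hand bears on why pyrrolidin-1-yl has this effect.

From the compounds shown here alone, whether the step belongs to pyrrolidin-1-yl itself or to any amine at this carbon stays open; a morpholine ring, a dimethylamino group or a simple methoxy there would separate the two. Also open, going by these compounds, is whether the same step appears on the core of compound 1, without the methoxy.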